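Aryl swap at the chain end of the piperazine amide

The source may hold more compounds than are shown below. What is called first, only, known or untested is meant among the compounds shown, and "the series" means these compounds.

Measured compounds:
compound 1, `CC(C)C[C@H](N)c1cc(C(F)(F)F)ccc1N1CCN(C(=O)CCc2ccccc2O)CC1`, 3300 nM in an assay on HEK293 cells for displacement of a labelled ligand from Melanocortin receptor 4 (Homo sapiens); a lower number here means a stronger inhibitor, a higher number a weaker inhibitor
compound 2, `CC(C)C[C@H](N)c1cc(C(F)(F)F)ccc1N1CCN(C(=O)CCc2ccc(S(C)(=O)=O)cc2)CC1`, 4900 nM in this assay

Both measured compounds share the core and differ only in the aromatic group on a saturated chain carbon, two bonds along the chain from a carbonyl carbon. Within the data shown here, compound 2 carries the 4-(methylsulfonyl)phenyl group and gives 4900 nM; its only neighbour is compound 1, and the step of a 1.5-fold higher number from compound 1 to compound 2 (0.17 log units; within the scatter) separates them, so the two numbers cannot be told apart.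

Compound 3, `CC(C)C[C@H](N)c1cc(C(F)(F)F)ccc1N1CCN(C(=O)CCc2csc3ccccc23)CC1`, is not yet measured. It differs from compound 2 as follows: 1-benzothiophen-3-yl in place of 4-(methylsulfonyl)phenyl on a saturated chain carbon, two bonds along the chain from a carbonyl carbon. Among the measured compounds shown here, the one step that bears on this change is a 1.5-fold higher number from compound 1 to compound 2 (0.17 log units; within the scatter), which also exchanged the aromatic group at that same place and stayed within the scatter. On that basis a further aryl exchange at this position is expected to move the number little, and the step of a 1.4-fold lower number from compound 2 to compound 3 (0.15 log units; within the scatter) is expected to stay within the scatter. Compound 3 is therefore estimated at 3500 nM, with a range from 1200 nM to 10000 nM.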

Compound 3, inhibition constant: 2300 nM
Compound 3: middle estimate off by 1.5-fold (0.18 log units), on the high side, and the stated range covers the measured number.
By their numbers in this assay, from the lowest: compounds 3, 1 and 2 (each within the scatter of the next, the first and the last beyond it).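

In this assay, among these compounds, replacing 4-(methylsulfonyl)phenyl with 1-benzothiophen-3-yl on a saturated chain carbon, two bonds along the chain from a carbonyl carbon, gives a 2.1-fold lower number from compound 2 to compound 3 (0.33 log units; beyond the scatter) and is the first exchange at this place to pass the scatter, though only modestly. Set against 2-hydroxyphenyl, the same group gives a 1.4-fold lower number from compound 1 to compound 3 (0.16 log units; within the scatter) and thus no separation, so the position's only resolved difference rests on a single pair, with compound 1 within the scatter of both other compounds. Nothing available accounts for the step, which exchanges the ring set and removes the methylsulfonyl group in one move.

Going by these compounds, it remains open whether the lower number in compound 3 follows from the presence of 1-benzothiophen-3-yl or from the absence of methylsulfonyl, a question that a plain phenyl group at this place could help to separate. Also open, on these data alone, is whether an amine or a carboxylic acid on the aromatic ring, or a longer chain between the carbonyl and that ring, would move the number further than these aryl exchanges do.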